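Swapping an aryl ether group for a hexyl chain

The source may report more compounds than this note shows. Statements on the series, on what has been measured and on what is new or still open speak of the compounds shown alone.

Compound 1 `[O-][n+]1nc(NCOCc2ccc(Cl)cc2)[n+]([O-])c2ccccc21`: 1470 nM
Compound 2 `COc1ccc(COCNc2n[n+]([O-])c3ccccc3[n+]2[O-])cc1`: 7640 nM
Compound 3 `COCNc1n[n+]([O-])c2ccccc2[n+]1[O-]`: 7450 nM

In a functional assay on A549 cells (Homo sapiens) for cytotoxicity, read by MTT assay, with a stated time of 72 h (a lower number here means a stronger inhibitor, a higher number a weaker inhibitor), compound 2 gives 7640 nM, the weak end of this small set, a place it shares with compound 3. Compound 4 `CCCCCCCOCNc1n[n+]([O-])c2ccccc2[n+]1[O-]` is not yet measured, and its change is hexyl in place of 4-methoxyphenyl on a saturated chain carbon bound to an oxygen on a saturated carbon. Within the data shown here, no measured step makes this exact swap. The nearest evidence is a 1.0-fold lower number from compound 2 to compound 3 (0.01 log units; within the scatter), where the 4-methoxyphenyl is simply lost. Against that stand a 5.2-fold higher number from compound 1 to compound 2 (0.72 log units; beyond the scatter) and a 5.1-fold higher number from compound 1 to compound 3 (0.70 log units; beyond the scatter), which show that the group at this end can shift the number modestly. A modest move towards a lower number is therefore expected, with the estimated step being a 2.2-fold lower number from compound 2 to compound 4 (0.34 log units; beyond the scatter). The estimated value for compound 4 is 3500 nM, expected between 1200 nM and 9000 nM.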

Compound 4, half-maximal inhibitory concentration: 2610 nM
Estimate against measurement, compound 4: 1.3-fold (0.13 log units) above; low and high end bracket the measured number.
By their numbers in this assay, from the lowest: compounds 1 and 4 (each within the scatter of the next); then compounds 3 and 2 (each within the scatter of the next).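

In this assay, the end group need not carry an aromatic ring for the number to fall: hexyl beats 4-methoxyphenyl (a 2.9-fold lower number from compound 2 to compound 4 (0.47 log units; beyond the scatter)) and also beats plain hydrogen (a 2.9-fold lower number from compound 3 to compound 4 (0.46 log units; beyond the scatter)). The ring-free hexyl also stands level with the 4-chlorophenyl group (a 1.8-fold higher number from compound 1 to compound 4 (0.25 log units; within the scatter)), so two very different groups serve about equally well here. No measurement shown gives a reason for these differences. Still open, on these data alone, is whether a longer chain would lower the number further, and whether an amine at the chain end would keep the gain.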